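A few compounds are considered here, and "the series" means these few. Any claim that something is new, unique, unknown or untested is made for them only; others in the source may bear on it.

Compound 1, `CC(C)n1ncc2c(C(=O)NCc3cn(-c4ccc(F)cc4)nn3)cccc21`: in a functional assay on MCF7 cells (Homo sapiens) for inhibition, read by MTT assay, with a stated time of 72 h (on this read-out higher numbers stand for weaker inhibition and lower numbers for stronger inhibition), compound 1 gives > 40000 nM, which is a limit of the assay rather than a number.
Compound 2, `CC(C)n1ncc2c(C(=O)NCc3cn(-c4cccc(F)c4)nn3)cccc21`: in this assay compound 2 gives > 40000 nM, again a limit of the assay.
Compound 3, `Cc1cccc(-n2cc(CNC(=O)c3cccc4c3cnn4C(C)C)nn2)c1`: in this assay compound 3 gives > 40000 nM, also a limit of the assay.

Compound 3 therefore stands nowhere in particular: its value is a limit, and it shares that position with every other compound measured, since (the limit of > 40000 nM in this assay, at which 3 of the 3 values shown sit). The change to compound 4, `CC(C)n1ncc2c(C(=O)NCc3cn(Cc4ccccc4)nn3)cccc21`, is benzyl in place of 3-methylphenyl on an aromatic nitrogen. Going by these compounds, the steps that were measured among the three known compounds all involve the group on that aromatic nitrogen, but none of them can be read: a step that the two limits leave unreadable from compound 1 to compound 2, a step that the two limits leave unreadable from compound 1 to compound 3 and a step that the two limits leave unreadable from compound 2 to compound 3 each run from one limit to another, so their sizes and directions are unknown. Among the compounds with values here, no measured step therefore says how a benzyl in place of a 3-methylphenyl should move the read-out in this assay; the only expectation is that compound 4 most likely ends at the same limit as the others. For compound 4 the estimate is 50000 nM, within 12000 nM to 200000 nM, meaning an expected step that the limit leaves unreadable from compound 3 to compound 4.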

Compound 4, half-maximal inhibitory concentration: 9170 nM
Compound 4: the middle estimate sits 5.5-fold (0.74 log units) above what was measured; measured number outside the range, below it.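

In this assay the change to benzyl on the aromatic nitrogen brings an at least 4.3-fold lower number from compound 3 to compound 4 (0.63 log units; beyond the scatter) and an at least 4.3-fold lower number from compound 2 to compound 4 (0.63 log units; beyond the scatter) and an at least 4.3-fold lower number from compound 1 to compound 4 (0.63 log units; beyond the scatter) at this position. Compound 3 and compound 4 hold the same atoms joined differently, so the read-out here depends on how those atoms are joined and not only on which atoms are present. Within the data shown here, compound 4 also supplies the only real number so far, against which later changes can be sized, while the others stay at a limit: the limit of > 40000 nM in this assay, at which 3 of the 4 values shown sit.

The steps among compound 1, compound 2 and compound 3 still cannot be read, so nothing shows how fluoro or methyl on the ring matters. Going by these compounds, whether a phenethyl group or a simple amine in place of benzyl on that aromatic nitrogen would lower the number further stays open.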